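The compounds below may be only part of what the source reports. "The series", "measured", "known", "first", "only" and "open" are said of these compounds alone.

Measured so far:
compound 1 `CN(C)CCn1cnnc1-c1cc(Oc2ccc(NC(=O)N/N=C/c3ccc(O)c(Br)c3)cc2F)ccn1` — 430 nM
compound 2 `CN(C)CCn1cnnc1-c1cc(Oc2ccc(NC(=O)N/N=C/c3ccccc3)cc2F)ccn1` — 1780 nM
compound 3 `CN(C)CCn1cnnc1-c1cc(Oc2ccc(NC(=O)N/N=C/c3cc(Br)c(O)c(Br)c3)cc2F)ccn1` — 3760 nM

In a functional assay on NCI-H460 cells (Homo sapiens) for cytotoxicity, read by MTT assay, with a stated time of 72 h (a lower number here means a stronger inhibitor, a higher number a weaker inhibitor), compound 2 holds the second highest of the three numbers; the nearer neighbour is compound 3, reached by a 2.1-fold higher number from compound 2 to compound 3 (0.32 log units; beyond the scatter), and the wider gap is the one covered by a 4.1-fold higher number from compound 1 to compound 2 (0.62 log units; beyond the scatter).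

Compound 4 `CN(C)CCn1cnnc1-c1cc(Oc2ccc(NC(=O)N/N=C/c3cccc(O)c3)cc2F)ccn1` has not been measured. It differs from compound 2 by hydroxy in place of hydrogen on an aromatic carbon.

Among the measured compounds shown here, two measured steps bear on this. One, a 4.1-fold higher number from compound 1 to compound 2 (0.62 log units; beyond the scatter), shows that removing a hydroxy together with a bromo raised the number. The other, a 2.1-fold higher number from compound 2 to compound 3 (0.32 log units; beyond the scatter), shows that adding a hydroxy together with two bromo raised it too. For the measured compounds named here, the single hydroxy of compound 4 thus has no clean precedent; a modest lowering of the number is expected, and compound 4 is estimated at 1000 nM (range 400 nM to 2500 nM), meaning an expected step of a 1.8-fold lower number from compound 2 to compound 4 (0.25 log units; within the scatter).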

Compound 4, half-maximal inhibitory concentration: 780 nM
Beside the measured number, compound 4's estimate is 1.3-fold (0.11 log units) above it; the measured number falls inside the stated range.
By their numbers in this assay, from the lowest: compounds 1 and 4 (each within the scatter of the next); then compound 2; then compound 3.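

In this assay, among the compounds shown here, a lone hydroxy meta to a large group lowers the number without any bromo (a 2.3-fold lower number from compound 2 to compound 4 (0.36 log units; beyond the scatter)), which the earlier steps, with hydroxy and bromo changing together, could not separate. The step to 3-bromo-4-hydroxyphenyl lies within the scatter (a 1.8-fold higher number from compound 1 to compound 4 (0.26 log units; within the scatter)), whereas 3,5-dibromo-4-hydroxyphenyl stands clearly apart (a 4.8-fold lower number from compound 3 to compound 4 (0.68 log units; beyond the scatter)). Nothing available gives a cause for these steps.

Open, on these data alone, is whether 4-hydroxyphenyl matches 3-hydroxyphenyl, and whether a methoxy, an amine or a carboxylic acid at this position would behave as hydroxy does.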